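From 4-methylbenzyl to 4-methoxybenzyl: working notes

The compounds below may be only part of what the source reports. "The series", "measured", "known", "first", "only" and "open" are said of these compounds alone.

compound 1 `Cc1cc(Nc2cc(-c3ccccc3)[nH]n2)n2nc(SCc3ccc(Br)cc3)nc2n1` gives 4760 nM
compound 2 `Cc1ccc(CSc2nc3nc(C)cc(Nc4cc(-c5ccccc5)[nH]n4)n3n2)cc1` gives 7310 nM

In a functional assay on PC-9 cells (Homo sapiens) for inhibition, read by MTT assay, with a stated time of 72 h (a higher number here means a weaker inhibitor, a lower number a stronger inhibitor), compound 2, at 7310 nM, stands within the scatter of compound 1. Compound 3 `COc1ccc(CSc2nc3nc(C)cc(Nc4cc(-c5ccccc5)[nH]n4)n3n2)cc1` carries methoxy in place of methyl on an aromatic carbon, para to a large group (methoxy in place of methyl on an aromatic carbon). Within the data shown here, one measured step bears on this place, methyl in place of bromo, and it is a 1.5-fold higher number from compound 1 to compound 2 (0.19 log units; within the scatter). On that single step, no change beyond the scatter is expected in this assay. The estimated step is a 1.2-fold lower number from compound 2 to compound 3 (0.09 log units; within the scatter). Compound 3 is expected at 6000 nM, with an estimated range of 2500 nM to 14000 nM.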

Compound 3, half-maximal inhibitory concentration: 8110 nM
Estimate against measurement, compound 3: 1.4-fold (0.13 log units) below; measured number inside the range.
By their numbers in this assay, from the lowest: compounds 1, 2 and 3 (each within the scatter of the next).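

In this assay, methoxy at this aromatic carbon is not separated from either earlier group: the steps are (a 1.1-fold higher number from compound 2 to compound 3 (0.05 log units; within the scatter)) and (a 1.7-fold higher number from compound 1 to compound 3 (0.23 log units; within the scatter)). With bromo, methyl and methoxy all in hand, the entry of a hydrogen-bond acceptor at this place brings no change beyond the scatter. No measured evidence bears on this result. Going by these compounds, whether an amine, a carboxylic acid or a longer alkoxy chain at this place would move the number beyond the scatter remains open.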